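The source may hold more compounds than are shown below. What is called first, only, known or untested is meant among the compounds shown, and "the series" means these compounds.

For the measured compounds named here, in a functional assay on K562 cells (Homo sapiens) for antiproliferative activity, read by CCK-8 assay, with a stated time of 72 h (a lower number here means a stronger inhibitor of growth, a higher number a weaker inhibitor of growth), compound 1 `CC[C@@H]1C(=O)N(C)c2cnc(-n3ccc4cc(C(N)=O)ccc43)nc2N1C1CCCC1` gives 1850 nM, the lowest of the three numbers measured so far and so the strongest growth inhibition in this small set. Compound 3 `CCCCNS(=O)(=O)c1ccc(Nc2ncc3c(n2)N(c2ccn(C)n2)C(CC)C(=O)N3C)cc1` gives 4240 nM and compound 2 `CCC1C(=O)N(C)c2cnc(-n3ccc4cc(C(=O)NC(C)C)ccc43)nc2N1c1ccn(C)n1` gives 8910 nM. Both gaps from compound 1 lie beyond the usual scatter of repeated measurements.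

The next compound, compound 4 `CCCNC(=O)c1ccc2c(ccn2-c2ncc3c(n2)N(C2CCCC2)[C@H](CC)C(=O)N3C)c1`, changes compound 1 in one place: propyl in place of hydrogen on an amide-type nitrogen. Going by the values given here, no measured pair shows this change on its own, so the expectation rests on thin evidence. The nearest hint is compound 2 at 8910 nM, which also carries a carbon group on an amide-type nitrogen but differs from compound 1 elsewhere too.

A small step towards weaker growth inhibition is therefore expected in this assay, possibly no larger than the scatter, estimated as a 1.4-fold higher number from compound 1 to compound 4 (0.15 log units; within the scatter). For compound 4 the estimated value is 2600 nM, with an expected range of 800 nM to 8500 nM.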

Compound 4, concentration for 50% growth inhibition: 395 nM
Estimate against measurement, compound 4: 6.6-fold (0.82 log units) above; the whole stated range lies above it.
By their numbers in this assay, from the lowest: compound 4; then compound 1; then compound 3; then compound 2.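

In this assay, putting propyl in place of the amide hydrogen, which turns carbamoyl into propylcarbamoyl, gives a 4.7-fold lower number from compound 1 to compound 4 (0.67 log units; beyond the scatter), so the change strengthens growth inhibition. For the compounds shown here, this is the first pair that isolates this position, and it shows that the amide hydrogen can be replaced and that a chain on this nitrogen is accepted with a gain rather than a loss. Nothing measured here accounts for the gain.

This is a single step with a single chain, so it gives no trend with chain length. As far as these compounds go, whether methyl, a longer chain such as pentyl, or a propyl chain ending in an amine or a carboxylic acid would go further in the same direction stays open.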